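Trimming One Methoxy Group: What to Expect for Compound 4

The source may hold more compounds than are shown below. What is called first, only, known or untested is meant among the compounds shown, and "the series" means these compounds.

Compound 3 `COc1ccc(C(=O)/C=C/c2cc(-c3cc(OC)c(OC)c(OC)c3)n[nH]2)cc1OC` was tested in a functional assay on U-251 cells (Homo sapiens) for inhibition, read by sulforhodamine B assay, with a stated time of 48 h (a lower number here means a stronger inhibitor of growth, a higher number a weaker inhibitor of growth), where compound 3 gives 2480 nM. Compound 1 `COc1cc(-c2cc(/C=C/C(=O)c3ccc(N)cc3)[nH]n2)cc(OC)c1OC` gives 2770 nM, and compound 2 `COc1cc(-c2cc(/C=C/C(=O)c3ccc(Cl)c(Cl)c3)[nH]n2)cc(OC)c1OC` gives 80500 nM. The two steps into compound 3 differ sharply: a 1.1-fold lower number from compound 1 to compound 3 (0.05 log units; within the scatter), whereas a 32-fold lower number from compound 2 to compound 3 (1.51 log units; beyond the scatter); likewise a 29-fold higher number from compound 1 to compound 2 (1.46 log units; beyond the scatter). Compound 4 `COc1ccc(C(=O)/C=C/c2cc(-c3cc(OC)c(OC)c(OC)c3)n[nH]2)cc1` differs from compound 3 by hydrogen in place of methoxy on an aromatic carbon. For the measured compounds named here, no measured step removes a single methoxy; each swaps the whole ring on a carbonyl carbon, so the large shifts seen there bear only loosely on this smaller change. The expectation for compound 4 is a step of a 1.4-fold higher number from compound 3 to compound 4 (0.15 log units; within the scatter), within the scatter or only slightly beyond it. Compound 4 is therefore estimated at 3500 nM, with a range from 1200 nM to 10000 nM.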

Compound 4, concentration for total growth inhibition: 2830 nM
Beside the measured number, compound 4's estimate is 1.2-fold (0.09 log units) above it; measured number inside the range.
By their numbers in this assay, from the lowest: compounds 3, 1 and 4 (each within the scatter of the next); then compound 2.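

In this assay, for the compounds shown here, this is the first step that removes a single methoxy, turning 3,4-dimethoxyphenyl into 4-methoxyphenyl, and the change stays within the scatter (a 1.1-fold higher number from compound 3 to compound 4 (0.06 log units; within the scatter)). Methoxy in place of amino at this ring position also stays within the scatter (a 1.0-fold higher number from compound 1 to compound 4 (0.01 log units; within the scatter)), whereas the change from 3,4-dichlorophenyl remains large (a 28-fold lower number from compound 2 to compound 4 (1.45 log units; beyond the scatter)). Nothing available explains why these changes differ in size. Still open, going by these compounds, is what happens with a hydroxy group or a longer ethoxy chain in place of this methoxy. Also open, on these data alone, is whether the remaining methoxy on this ring can be replaced by hydrogen.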